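Expected Ear Inhibition for Compound 4

This account rests on a few compounds, and the source may have more. Where it says the series, first, only, none or still open, it means among the compounds named here.

Of the compounds shown here, three have been measured in a functional assay on the whole organism (Ear) for inhibition, with Mus musculus as the target, with a stated time of 30 min, at a dose of 100 mg/kg by the intraperitoneal route; a higher number here means more inhibition at the dose given (going by the name of the read-out), a lower number less inhibition. Compound 2 `N=C(N)N/N=C/c1ccc(/C=C/C(=O)c2ccc(Cl)cc2Cl)cc1` gives 92.5%. Compound 1 `O=C(N/N=C/c1ccc(/C=C/C(=O)c2ccc(Cl)cc2Cl)cc1)c1ccncc1` gives 83.8%, and compound 3 `N=C(N)N/N=C/c1ccc(/C=C/C(=O)c2ccccc2Br)cc1` gives 78.3% in this assay, the lowest of the three numbers, though its gap to compound 1 is within the scatter.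

Two single changes link them. From compound 2 to compound 1 the change is a group of 8 heavy atoms (6 carbon, 1 nitrogen, 1 oxygen; one six-membered aromatic ring with 1 hetero atom) in place of a group of 3 heavy atoms (1 carbon, 2 nitrogen; no ring), on an amine nitrogen, and this step is a number 8.7 percentage points lower from compound 2 to compound 1 (within the scatter). From compound 2 to compound 3 the cores differ by 2-bromophenyl in place of 2,4-dichlorophenyl on a carbonyl carbon, a step of a number 14.2 percentage points lower from compound 2 to compound 3 (beyond the scatter).

Compound 4 `O=C(N/N=C/c1ccc(/C=C/C(=O)c2ccccc2Br)cc1)c1ccncc1` is not yet measured. It differs from compound 3 by a group of 8 heavy atoms (6 carbon, 1 nitrogen, 1 oxygen; one six-membered aromatic ring with 1 hetero atom) in place of a group of 3 heavy atoms (1 carbon, 2 nitrogen; no ring), on an amine nitrogen, the same change as from compound 2 to compound 1, at the same place. The expectation for compound 4 rests on that earlier step, because a number 8.7 percentage points lower from compound 2 to compound 1 (within the scatter) was small and within the scatter, so a similar small step is estimated here, a number 8.3 percentage points lower from compound 3 to compound 4 (within the scatter). Compound 4 is therefore expected to give about 70% in this assay, estimated between 57% and 83%.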

Compound 4, a percentage reported as inhibition, in the whole organism at one dose (the size of the read-out at that dose, not a potency): 48.7%
Beside the measured number, compound 4's estimate is 21.3 percentage points above it; the measured number lies below the stated range.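

In this assay, the entry of (pyridin-4-yl)carbonyl on the amine nitrogen did not carry over at one size from one core to the other, with a number 29.6 percentage points lower from compound 3 to compound 4 (beyond the scatter) set against the earlier, smaller step: the same change on two cores in this assay, a number 8.7 percentage points lower (within the scatter) from compound 2 to compound 1 and a number 29.6 percentage points lower (beyond the scatter) from compound 3 to compound 4, 20.9 percentage points apart, beyond the scatter of two such steps.
Read the other way, 2-bromophenyl in place of 2,4-dichlorophenyl on the carbonyl carbon also changes in size with the group on the amine nitrogen, giving a number 35.1 percentage points lower from compound 1 to compound 4 (beyond the scatter): the same change on two cores in this assay, a number 14.2 percentage points lower (beyond the scatter) from compound 2 to compound 3 and a number 35.1 percentage points lower (beyond the scatter) from compound 1 to compound 4, 20.9 percentage points apart, beyond the scatter of two such steps.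
The direction is the same on both cores, so these four compounds show that the two changes do not simply add up, but they do not show what sets the size of the step or whether the same holds on any other core.

The compounds shown leave open whether this dependence extends to other groups on the amine nitrogen, such as a plain acetyl or (pyridin-3-yl)carbonyl. They also leave open how a simple phenyl or 4-chlorophenyl on the carbonyl carbon would behave with each of the two groups.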